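Cyclopropyloxy for cyclobutyloxy on a methylated indole analogue

The compounds below may be only part of what the source reports. "The series", "measured", "known", "first", "only" and "open" are said of these compounds alone.

Measured compounds:
compound 1, `COc1cc(-c2nnc3c(OC4CCC4)cc(-c4ccc5[nH]ccc5c4)cn23)cc(OC)c1OC`, 694 nM
compound 2, `COc1cc(-c2nnc3c(OC4CC4)cc(-c4ccc5[nH]ccc5c4)cn23)cc(OC)c1OC`, 275 nM
compound 3, `COc1cc(-c2nnc3c(OC4CCC4)cc(-c4ccc5c(ccn5C)c4)cn23)cc(OC)c1OC`, 750 nM

Of the compounds shown here, three of one series have been tested in a functional assay on HCT-116 cells (Homo sapiens) for antiproliferative activity, read by MTT assay, with a stated time of 48 h; on this read-out lower numbers stand for stronger inhibition and higher numbers for weaker inhibition. Compound 1 `COc1cc(-c2nnc3c(OC4CCC4)cc(-c4ccc5[nH]ccc5c4)cn23)cc(OC)c1OC` gives 694 nM in this assay. Compound 2 `COc1cc(-c2nnc3c(OC4CC4)cc(-c4ccc5[nH]ccc5c4)cn23)cc(OC)c1OC` differs from compound 1 by cyclopropyl in place of cyclobutyl on an oxygen on an aromatic ring, and this change brought a 2.5-fold lower number from compound 1 to compound 2 (0.40 log units; beyond the scatter). Compound 3 `COc1cc(-c2nnc3c(OC4CCC4)cc(-c4ccc5c(ccn5C)c4)cn23)cc(OC)c1OC` differs from compound 1 in its core by methyl in place of hydrogen on an aromatic nitrogen; here the step was a 1.1-fold higher number from compound 1 to compound 3 (0.03 log units; within the scatter), so the values of compound 1 and compound 3 cannot be told apart.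

Compound 4 `COc1cc(-c2nnc3c(OC4CC4)cc(-c4ccc5c(ccn5C)c4)cn23)cc(OC)c1OC` has not yet been measured in this assay. It relates to compound 3 as compound 2 relates to compound 1: the change is cyclopropyl in place of cyclobutyl on an oxygen on an aromatic ring, made on the core of compound 3 rather than on that of compound 1. Among the compounds with values here, since the place of the change reads the same in both pairs, it is the same change, and the single prior example is the step from compound 1 to compound 2. Because the change from compound 1 to compound 2 gave a 2.5-fold lower number from compound 1 to compound 2 (0.40 log units; beyond the scatter), a step of similar size is expected here, so that the estimated step is a 2.5-fold lower number from compound 3 to compound 4 (0.40 log units; beyond the scatter). Within the data shown here, the one earlier instance is the sole basis, so the expectation is tentative. Compound 4 is accordingly estimated at 300 nM in this assay, with an expected range from 150 nM to 600 nM.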

Compound 4, half-maximal inhibitory concentration: 135 nM
The estimate for compound 4 lay 2.2-fold (0.35 log units) above the measured number; the measured number lies below the stated range.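

In this assay, cyclopropyl in place of cyclobutyl on the oxygen gave a 5.6-fold lower number from compound 3 to compound 4 (0.74 log units; beyond the scatter) on the methylated core, the same direction as on the core of compound 1, and the two steps cannot be told apart in size: the same change on two cores in this assay, a 2.5-fold lower number (0.40 log units; beyond the scatter) from compound 1 to compound 2 and a 5.6-fold lower number (0.74 log units; beyond the scatter) from compound 3 to compound 4, 2.2-fold (0.34 log units) apart, within the scatter of two such steps. Methyl in place of hydrogen on the aromatic nitrogen gave a 2.0-fold lower number from compound 2 to compound 4 (0.31 log units; beyond the scatter) in the cyclopropyloxy pair, while in the cyclobutyloxy pair it made no readable difference, yet these two steps cannot be told apart either: the same change on two cores in this assay, a 1.1-fold higher number (0.03 log units; within the scatter) from compound 1 to compound 3 and a 2.0-fold lower number (0.31 log units; beyond the scatter) from compound 2 to compound 4, 2.2-fold (0.34 log units) apart, within the scatter of two such steps. The change from cyclobutyloxy to cyclopropyloxy therefore carried over to the second core in direction, but the larger step on that core does not show a stronger effect there, nor do the two changes demonstrably reinforce each other, and two cores cannot show that the transfer holds across the series.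

The compounds shown leave open whether a cyclopentyl group, an isopropyl group or a longer chain on the same oxygen would continue the trend from cyclobutyl to cyclopropyl. They also leave open what an ethyl group or a chain ending in an amine would do on the aromatic nitrogen in place of methyl.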